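Swapping Trifluoromethyl for Chloro on the Aryl Ring

A few compounds are considered here, and "the series" means these few. Any claim that something is new, unique, unknown or untested is made for them only; others in the source may bear on it.

Compound 2 `CC(C(=O)N1CCN(c2cccc(C(F)(F)F)c2)CC1)N1C(=O)CCC1=O` gives 88.4 mg/kg in a functional assay on the whole organism (strain Swiss) with Mus musculus as the target, in the maximal electroshock model, with a stated time of 0.5 h; a higher number here means that more compound is needed for the effect, a lower number that less compound is needed. Among the three measured compounds it stands second highest: its nearest neighbour is compound 1 `COCC(C(=O)N1CCN(c2cccc(C(F)(F)F)c2)CC1)N1C(=O)CCC1=O`, which gives 85.1 mg/kg, and the furthest is compound 3 `CCC(C(=O)N1CCN(c2cccc(Cl)c2)CC1)N1C(=O)CCC1=O`, which gives 138 mg/kg. Among the measured compounds shown here, the one measured step, a 1.0-fold higher number from compound 1 to compound 2 (0.02 log units; within the scatter), shows that the exchange on the chain carbon left the dose essentially where it was. Compound 4 `CC(C(=O)N1CCN(c2cccc(Cl)c2)CC1)N1C(=O)CCC1=O` differs from compound 2 by chloro in place of trifluoromethyl on an aromatic carbon. For the measured compounds named here, no measured step isolates this exchange. Compound 3 also carries chloro, but it differs from compound 2 in two places, so its value can only be set beside that of compound 2, and the two numbers lie within the usual scatter of each other. Going by the values given here, with the only measured step within the scatter and at another site, no step beyond the scatter is expected in this assay for this change. Compound 4 is therefore expected to give about 105 mg/kg, between 55 mg/kg and 200 mg/kg. The expected step is a 1.2-fold higher number from compound 2 to compound 4 (0.07 log units; within the scatter).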

Compound 4, dose for half-maximal effect: 119 mg/kg
Beside the measured number, compound 4's estimate is 1.1-fold (0.05 log units) below it, and the stated range covers the measured number.
By their numbers in this assay, from the lowest: compounds 1, 2, 4 and 3 (each within the scatter of the next).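

In this assay, chloro in place of trifluoromethyl on an aromatic carbon, meta to a large group, gives a 1.3-fold higher number from compound 2 to compound 4 (0.13 log units; within the scatter), so this ring exchange, now seen on its own, does not move the dose beyond the scatter. With chloro held on the ring, hydrogen in place of methyl on the saturated chain carbon gives a 1.2-fold lower number from compound 3 to compound 4 (0.06 log units; within the scatter), so the chain site also shows no step beyond the scatter in the chloro series, as it did with methoxy and trifluoromethyl. Nothing available bears on what lies behind these small steps.

On these data alone, it remains open whether an amine or a carboxylic acid in place of chloro on the aromatic ring would shift the dose beyond the scatter. The same question stands for a longer chain or a hydroxyl group on the saturated chain carbon.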